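This account rests on a few compounds, and the source may have more. Where it says the series, first, only, none or still open, it means among the compounds named here.

Compound 1 `CCCc1ccc(/C=C2\CCCN=C2c2cccnc2)cc1` was tested in an assay on membranes from brain for displacement of a labelled ligand from Neuronal acetylcholine receptor; alpha4/beta2 (Rattus norvegicus), with a stated time of 3 h (on this read-out lower numbers stand for stronger inhibition and higher numbers for weaker inhibition), where compound 1 gives 890 nM. Among the measured compounds shown here, only one other number is known: compound 2 `COc1ccc2cc(/C=C3\CCCN=C3c3cccnc3)ccc2c1` in this assay gives 600 nM, and the two lie within the usual scatter of repeated measurements of each other. Compound 3 `CSc1ccc(/C=C2\CCCN=C2c2cccnc2)cc1` differs from compound 1 in one place: methylsulfanyl in place of propyl on an aromatic carbon. For the measured compounds named here, no measured pair shows the effect of such a swap, so compound 1 alone is the guide. The step of a 1.3-fold lower number from compound 1 to compound 3 (0.10 log units; within the scatter) is expected to stay within the scatter, in either direction. For compound 3 the estimated value is 700 nM, with a range from 250 nM to 2000 nM.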

Compound 3, inhibition constant: 900 nM
Compound 3: middle estimate off by 1.3-fold (0.11 log units), on the low side; low and high end bracket the measured number.
By their numbers in this assay, from the lowest: compounds 2, 1 and 3 (each within the scatter of the next).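

In this assay methylsulfanyl in place of propyl gives a 1.0-fold higher number from compound 1 to compound 3 (0.00 log units; within the scatter) and so the two groups cannot be told apart on this aromatic carbon. The earlier compounds shown here held no such pair; this one shows that a group with fewer heavy atoms, a sulfur and a hydrogen-bond acceptor keeps the number within the scatter of the propyl compound. No measurement at hand offers a reason for this result. On these data alone, whether an amine or a carboxylic acid on this carbon would move the number stays open. So does the outcome for a longer chain.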